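Naphthalenyl in Place of Fluorophenyl on an Amine Nitrogen

A few compounds are considered here, and "the series" means these few. Any claim that something is new, unique, unknown or untested is made for them only; others in the source may bear on it.

compound 1, `C=C1[C@@H](OC(C)=O)C[C@@H]2[C@](C)(CO[Si](C)(C)C(C)(C)C)[C@H](OC(C)=O)CC[C@@]2(C)[C@@H]1C[C@@H](Nc1ccccc1F)C1=CCOC1=O`: 2930 nM
compound 2, `C=C1[C@@H](OC(C)=O)C[C@@H]2[C@](C)(COC=O)[C@H](OC(C)=O)CC[C@@]2(C)[C@@H]1C[C@@H](Nc1ccc(O)cc1)C1=CCOC1=O`: 18100 nM

In a functional assay on MCF7 cells (Homo sapiens) for cytotoxicity, read by sulforhodamine B assay (on this read-out higher numbers stand for weaker inhibition and lower numbers for stronger inhibition), compound 1 stands lowest of the two numbers, and compound 2 lies beyond the scatter above it. Compound 3, `C=C1[C@@H](OC(C)=O)C[C@@H]2[C@](C)(CO[Si](C)(C)C(C)(C)C)[C@H](OC(C)=O)CC[C@@]2(C)[C@@H]1C[C@@H](Nc1cccc2ccccc12)C1=CCOC1=O`, shares the core of compound 1 and differs from it in one place: naphthalen-1-yl in place of 2-fluorophenyl on an amine nitrogen. Among the measured compounds shown here, no measured pair shows this change, so the size of its step is open. A step no larger than the usual scatter is expected, in either direction, estimated as a 1.2-fold higher number from compound 1 to compound 3 (0.08 log units; within the scatter). Compound 3 is therefore expected near 3500 nM, in a range from 1000 nM to 12000 nM.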

Compound 3, half-maximal inhibitory concentration: 5770 nM
The estimate for compound 3 lay 1.6-fold (0.22 log units) below the measured number; measured number inside the range.
By their numbers in this assay, from the lowest: compounds 1 and 3 (each within the scatter of the next); then compound 2.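

In this assay, naphthalen-1-yl in place of 2-fluorophenyl on an amine nitrogen gives a 2.0-fold higher number from compound 1 to compound 3 (0.29 log units; within the scatter). At this position, then, a group with two six-membered aromatic rings and no fluorine stays within the scatter of the 2-fluorophenyl group on the core of compound 1. Nothing measured here gives a reason for this result.

From the compounds shown here alone, it remains open how a saturated group such as cyclohexyl, or a benzyl group, would read on this nitrogen. Compound 2 differs from compound 1 in more than one place, so it cannot isolate the effect of either change.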